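Swapping the group on sulfur in compound 1

The source may report more compounds than this note shows. Statements on the series, on what has been measured and on what is new or still open speak of the compounds shown alone.

Compound 1 `Nc1ccccc1NC(=O)/C=C/c1ccc(CSc2cccc(F)c2)cc1` has been measured in a functional assay on HCT-116 cells (Homo sapiens) for inhibition, read by CCK-8 assay, with a stated time of 72 h, tested at 8 uM (on this read-out higher numbers stand for more inhibition of growth at the one concentration tested and lower numbers for less inhibition of growth), and there compound 1 gives 3.22%. Going by the values given here, only one other compound has a number so far: compound 2 `Cc1ccc(SCc2ccc(C(=O)Nc3ccccc3N)cc2)cc1` gives 84%. Compound 1 therefore holds the lower of the two values, and the gap between them lies well beyond the usual scatter of such measurements. Among the compounds with values here, no two measured compounds differ in just one place, so no measured step is available as a guide.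

Compound 3 `Nc1ccccc1NC(=O)/C=C/c1ccc(CSCCc2ccccc2)cc1` keeps the core of compound 1 and changes one group, with phenethyl in place of 3-fluorophenyl on a sulfur. Neither group carries a net charge.

For this assay, a modest rise is expected, though it may not exceed the scatter. With compound 1 at 3.22%, the number has little room to fall, so an upward direction is the more likely one. The estimated size of the change is a number 8.8 percentage points higher from compound 1 to compound 3 (within the scatter). For compound 3, the expected value is 12%, within an estimated range of 0% to 40%.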

Compound 3, percent growth inhibition at one concentration: 10.6%
The estimate for compound 3 lay 1.4 percentage points above the measured number; measured number inside the range.
By their numbers in this assay, from the lowest: compounds 1 and 3 (each within the scatter of the next); then compound 2.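

In this assay, the swap at this sulfur gives a step of a number 7.4 percentage points higher from compound 1 to compound 3 (within the scatter), so on this read-out compound 3 cannot be told apart from compound 1. Phenethyl differs from 3-fluorophenyl by carrying no fluorine and by having more carbon, yet the two groups share one six-membered aromatic ring of carbon only, no hydrogen-bond donors or acceptors and no net charge, and this one exchange does not separate the pair at the single concentration tested. No measurement is available here that bears on why the two compounds read alike.

Still open is whether this position on sulfur responds to a group of a different kind, such as an aminoethyl chain, a carboxylic acid or a small methyl group, since both groups shown here carry an aromatic ring of carbon only. Also open, on these data alone, is what the fluorine and the added carbon each contribute on their own, which a plain phenyl or a benzyl group on the same sulfur could begin to separate.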